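The source may hold more compounds than are shown below. What is called first, only, known or untested is meant among the compounds shown, and "the series" means these compounds.

In a functional assay, read by spectrophotometry, with a stated time of 3 min (a higher number here means a weaker inhibitor, a lower number a stronger inhibitor), compound 1 `Nc1ccccc1/N=C\c1cc(=O)oc2cc(OCc3ccccc3)cc(OCc3ccccc3)c12` gives 7530 nM and compound 2 `Nc1ccccc1/N=C\c1cc(=O)oc2cc(OCc3ccccc3)ccc12` gives 9250 nM, so these two lie within the usual scatter of each other. Compound 3 `O=c1cc(/C=N\Nc2ccc([N+](=O)[O-])cc2[N+](=O)[O-])c2c(OCc3ccccc3)cc(OCc3ccccc3)cc2o1` is recorded as "not active" (no number reported), with no number. Compound 4 `O=c1cc(/C=N\c2ccccc2O)c2ccc(OCc3ccccc3)cc2o1` differs from compound 2 in one place: hydroxy in place of amino on an aromatic carbon. In words, this is hydroxy in place of amino on an aromatic carbon. Among the measured compounds shown here, no measured step makes this swap. The only one available, a 1.2-fold higher number from compound 1 to compound 2 (0.09 log units; within the scatter), is hydrogen in place of benzyloxy on an aromatic carbon, so it bears on the swap only loosely. No shift beyond the scatter is therefore expected in this assay, and the estimated step is a 1.1-fold higher number from compound 2 to compound 4 (0.03 log units; within the scatter). For compound 4 the estimate is 10000 nM, with an expected range of 3500 nM to 30000 nM.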

Compound 4, half-maximal inhibitory concentration: 1290 nM
Compound 4: middle estimate off by 7.8-fold (0.89 log units), on the high side; measured number below the stated range.
By their numbers in this assay, from the lowest: compound 4; then compounds 1 and 2 (each within the scatter of the next).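

In this assay the change from 2-aminophenyl to 2-hydroxyphenyl gives a 7.2-fold lower number from compound 2 to compound 4 (0.86 log units; beyond the scatter) and so, unlike the loss of a benzyloxy group, moves the number beyond the scatter. Both groups count one hydrogen-bond donor and one hydrogen-bond acceptor, so those counts do not separate them. Nothing available accounts for the shift. Still open, going by these compounds, is whether a methoxy or a thiol at this place would match the hydroxy. Also open, on these data alone, is whether the same swap has a similar effect on the core of compound 1, with its second benzyloxy group.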